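Half-life in buffer from a vinylsulfone to a bromomethyl ketone

The source may report more compounds than this note shows. Statements on the series, on what has been measured and on what is new or still open speak of the compounds shown alone.

Compound 1 `C=CS(=O)(=O)c1cc(C(F)(F)F)cc(C(F)(F)F)c1`: < 0.017 h in an ADME assay for pharmacokinetics, read by LC-MS, in phosphate buffer, with a stated time of 72 h, at pH 7.4, tested at 250 uM; a lower number here means that the compound disappears faster, a higher number that the compound lasts longer
Compound 2 `C=Cc1cc(C(F)(F)F)cc(C(F)(F)F)c1`: > 50 h

In this assay compound 1 gives only a limit, < 0.017 h, as noted at the limit of < 0.017 h in this assay, at which 1 of the 2 values shown sits. Compound 2 likewise gives only a limit, > 50 h, which is the other end of the range at the limit of > 50 h in this assay, at which 1 of the 2 values shown sits. Among the measured compounds shown here, the one measured step, an at least 2900-fold higher number from compound 1 to compound 2 (3.46 log units; beyond the scatter), is therefore at least as large as the two limits allow, and compound 2 stands at the long-lived end of what has been seen.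

Compound 3 `O=C(CBr)c1cc(C(F)(F)F)cc(C(F)(F)F)c1` differs from compound 2 as follows: (bromomethyl)carbonyl in place of vinyl on an aromatic carbon. For the measured compounds named here, no measured step changes this group, so the step from compound 1 to compound 2 bears on it only by showing that a group on this carbon can move the half-life over the whole measured range. A shorter half-life than compound 2 is expected, with wide uncertainty, and compound 3 is estimated at 2 h, between 0.05 h and 40 h, a step of an at least 25-fold lower number from compound 2 to compound 3 (1.39 log units; beyond the scatter).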

Compound 3, half-life: < 0.017 h
Compound 3 was reported as a limit (the forecaster's own chance of this, stated with the estimate: 25%); middle value at least 110-fold (2.07 log units) from the limit.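

In this assay compound 3 gives < 0.017 h, which is a limit of the assay and not a number. Placing (bromomethyl)carbonyl instead of vinyl on this aromatic carbon gives an at least 2900-fold lower number from compound 2 to compound 3 (3.46 log units; beyond the scatter), so a second group besides vinylsulfonyl now shows that the short-lived end of the range can be reached from this carbon. Compound 1 and compound 3 share that end, and the step between them cannot be read: the limit of < 0.017 h in this assay, at which 2 of the 3 values shown sit.

As far as these compounds go, how far the half-lives of compound 1 and compound 3 lie past that limit remains open, and so does which of the two disappears faster. Also open, from the compounds shown here alone, is whether a smaller carbonyl group on this carbon, such as acetyl, or a chloromethyl ketone, would give a half-life that falls inside the span between the two limits.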